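The source may report more compounds than this note shows. Statements on the series, on what has been measured and on what is new or still open speak of the compounds shown alone.

Measured compounds:
compound 1, `CC(C)NC(=O)c1ccc(C#Cc2ccccc2)nc1`: 7100 nM
compound 2, `CC(C)N1CCc2nc(C#Cc3ccccc3)ccc2C1=O`: 1280 nM

In an assay on HEK293 cells for displacement of a labelled ligand from metabotropic glutamate receptor 5 (Homo sapiens), with a stated time of 2 h (on this read-out higher numbers stand for weaker inhibition and lower numbers for stronger inhibition), compound 2 gives the lower of the two numbers; compound 1 gives the higher one, and that gap lies beyond the scatter. Compound 3, `CC(C)N1CCc2nc(C#Cc3cccs3)ccc2C1=O`, is not yet measured. It differs from compound 2 by thiophen-2-yl in place of phenyl on a triple-bonded carbon. Going by the values given here, no step between two measured compounds covers this change, so in this assay a shift within the scatter is expected, with no firm direction. The expected step is a 1.3-fold lower number from compound 2 to compound 3 (0.11 log units; within the scatter). Compound 3 is thus estimated at 1000 nM, within 400 nM to 2500 nM.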

Compound 3, inhibition constant: 1930 nM
The estimate for compound 3 lay 1.9-fold (0.29 log units) below the measured number; measured number inside the range.
By their numbers in this assay, from the lowest: compounds 2 and 3 (each within the scatter of the next); then compound 1.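

Thiophen-2-yl in place of phenyl on a triple-bonded carbon gives a 1.5-fold higher number from compound 2 to compound 3 (0.18 log units; within the scatter) in this assay. This position therefore accepts a five-membered aromatic ring with 1 hetero atom as well as a six-membered aromatic ring of carbon only, with no change readable beyond the scatter. No measured information bears on this result. Still open, from the compounds shown here alone, is whether a pyridin-2-yl group or a phenyl carrying fluorine or methoxy at this position moves the number beyond the scatter. Going by these compounds, whether thiophen-2-yl behaves alike on the core of compound 1 also remains open.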